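Pyrimidine for Biphenyl on an Amide-Bearing Core

The compounds below may be only part of what the source reports. "The series", "measured", "known", "first", "only" and "open" are said of these compounds alone.

Compound 1 `CCOC(=O)CCCCCOc1cccc(CN(C(=O)c2ccc(-c3cccc(NC(C)=O)c3)cc2)C(C)C)c1`: > 26000 nM, a limit
Compound 2 `CCOC(=O)CCCCCOc1cccc(CN(C(=O)c2ccc(-c3cccc(-c4ccccc4)c3)cc2)C(C)C)c1`: > 26000 nM, a limit

In an ADME assay on HEK293 cells (Homo sapiens) for cytotoxicity, read by CellTiter-Glo and resazurin assay, with a stated time of 72 h (on this read-out higher numbers stand for an effect only at larger amounts of compound and lower numbers for an effect already at smaller amounts), compound 1 reaches only a limit, > 26000 nM. In the same assay compound 2 also reaches only a limit, > 26000 nM. The change from compound 1 to compound 2, phenyl in place of acetamido on an aromatic carbon, gives a step that the two limits leave unreadable from compound 1 to compound 2. Both numbers sit at the limit of > 26000 nM in this assay, at which 2 of the 2 values shown sit, so compound 2 stands where every measured compound here stands, at the edge of what this assay reports.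

Compound 3 `CCOC(=O)CCCCCOc1cccc(CN(C(=O)c2ccc(-c3cnc(OC)nc3OC)cc2)C(C)C)c1` carries the change (2,4-dimethoxypyrimidin-5-yl in place of 3-phenylphenyl on an aromatic carbon). Within the data shown here, no measured step bears on this change, since the one step known is unreadable between two limits. Compound 3 is therefore expected to give 30000 nM, in a range from 8000 nM to 100000 nM. The step from compound 2 to compound 3 is expected to be a step that the limit leaves unreadable from compound 2 to compound 3.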

Compound 3, half-maximal effective concentration: > 26000 nM
Compound 3: no number, only a limit (the forecaster's own chance of this, stated with the estimate: 80%); the middle value lies beyond the limit too.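

Compound 3 reads as a limit in this assay, as do compound 1 and compound 2, so no step among the three can be read: the limit of > 26000 nM in this assay, at which 3 of the 3 values shown sit.

The compounds shown leave open whether exchanging these groups changes the read-out in this assay at all.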